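Amide nitrogen substituent swap in the phosphatase inhibitor series

This account rests on a few compounds, and the source may have more. Where it says the series, first, only, none or still open, it means among the compounds named here.

The series is followed in an assay on isolated protein for inhibition of tyrosine-protein phosphatase non-receptor type 13 (Homo sapiens), read by spectrophotometry; a lower number here means a stronger inhibitor, a higher number a weaker inhibitor. Compound 1 `Oc1cc(-c2ccccc2)ccc1C(O)(C(F)(F)F)C(F)(F)F` returns only a limit of that assay, > 500000 nM. Among the measured compounds shown here, compound 2 `O=C(COc1ccc2cc(C(O)(C(F)(F)F)C(F)(F)F)c(O)cc2c1)Nc1nc2ccccc2s1` gives 9900 nM in this assay, the only number so far. Compound 1 sits at the limit of > 500000 nM in this assay, at which 1 of the 2 values shown sits. Compound 3 `CCCNC(=O)COc1ccc2cc(C(O)(C(F)(F)F)C(F)(F)F)c(O)cc2c1` is not yet measured; it differs from compound 2 by propyl in place of 1,3-benzothiazol-2-yl on an amide-type nitrogen, in words propyl in place of 1,3-benzothiazol-2-yl on an amide-type nitrogen. No step between measured compounds covers this change, so nothing shown can be read as a cause. The step is nevertheless expected to lie beyond the usual scatter, toward weaker inhibition, with an expected 6.1-fold higher number from compound 2 to compound 3 (0.78 log units; beyond the scatter). Compound 3 is estimated at 60000 nM in this assay, with a likely range from 12000 nM to 300000 nM, and a real chance that the assay reports only a limit.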

Compound 3, half-maximal inhibitory concentration: > 20000 nM
Compound 3: a limit, no number; the forecaster's own chance of this, stated with the estimate: 30%; the middle value does not contradict the limit.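

Compound 3 returns only a limit in this assay, > 20000 nM, and not a number. With propyl in place of 1,3-benzothiazol-2-yl on the amide-type nitrogen, the change reads as an at least 2.0-fold higher number from compound 2 to compound 3 (0.30 log units; that floor lies within the scatter), so only a floor is known and a loss beyond the scatter is not established. Even so, this first reading at this position shows no gain from propyl, and compound 2 remains the only compound in the series with a measured number.

From the compounds shown here alone, the true size of the step remains open, as does whether the fused aromatic ring system of compound 2 is needed at all. A phenyl group, or a longer chain ending in a carboxylic acid, on the same nitrogen would help separate these possibilities.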